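Phenyl to benzyl on an amide-type nitrogen: working notes

This account rests on a few compounds, and the source may have more. Where it says the series, first, only, none or still open, it means among the compounds named here.

Measured compounds:
compound 1 `O=C(NCc1ccccc1)Oc1ccc(Cl)cc1C(=O)Nc1ccc(Cl)cc1`: > 250000 nM
compound 2 `O=C(Nc1ccccc1)Oc1ccc(Cl)cc1C(=O)Nc1ccc(Cl)cc1`: > 250000 nM
compound 3 `O=C(Nc1ccccc1)Oc1ccccc1C(=O)Nc1ccccc1`: 57700 nM

All three were run in an ADME assay on HepG2 cells (Homo sapiens) for cytotoxicity, read by MTT assay; a lower number here means a stronger inhibitor, a higher number a weaker inhibitor. For compound 1 the value > 250000 nM is a limit of this assay, not a number. For compound 2 the value > 250000 nM is likewise a limit. Compound 3 is the only one of the three that gives a number, 57700 nM.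

The step that the two limits leave unreadable from compound 2 to compound 1 carries the change (benzyl in place of phenyl on an amide-type nitrogen); its size is not readable because of the limit of > 250000 nM in this assay, at which 2 of the 3 values shown sit. The difference between the core of compound 3 and the core of compound 2 is not broken down here.

Compound 4 `O=C(NCc1ccccc1)Oc1ccccc1C(=O)Nc1ccccc1` is not yet measured. It differs from compound 3 by benzyl in place of phenyl on an amide-type nitrogen, the same change at the same place as that from compound 2 to compound 1. Within the data shown here, with the only measured instance of this change giving no readable size, the step expected here is a 1.0-fold higher number from compound 3 to compound 4 (0.02 log units; within the scatter), taken as small. Compound 4 is estimated at 60000 nM, with a likely range from 20000 nM to 200000 nM.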

Compound 4, half-maximal inhibitory concentration: > 125000 nM
Compound 4 was reported as a limit; the forecaster's own chance of this, stated with the estimate: 25%; middle value at least 2.0-fold (0.31 log units) away from the limit.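

In this assay, benzyl in place of phenyl on an amide-type nitrogen gives an at least 2.1-fold higher number from compound 3 to compound 4 (0.33 log units; beyond the scatter), so on the core of compound 3 the change moves the number upward. Compound 4 gives > 125000 nM, which is a limit of the assay and not a number, so the step has a floor but no readable size. The same change on the core of compound 2 cannot be read because compound 1 and compound 2 both sit at a limit, so the data do not show whether the size of the step carries over from one core to the other: the limit of > 250000 nM in this assay, at which 2 of the 4 values shown sit.

From the compounds shown here alone, it remains open how the series responds when the phenyl is replaced by a longer chain, such as phenethyl, or by a chain ending in an amine or a carboxylic acid. Also open, going by these compounds, is how large this change is on any core where both partners give a number rather than a limit.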